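This account rests on a few compounds, and the source may have more. Where it says the series, first, only, none or still open, it means among the compounds named here.

For the measured compounds named here, compound 2 `COc1ccc(CNC(=O)c2cc(Oc3ccc(/C=C/c4ccccn4)cc3)ccn2)cc1` is the weaker of the two compounds measured so far in a functional assay on A549 cells (Homo sapiens) for antiproliferative activity, read by CCK-8 assay, with a stated time of 48 h; a higher number here means a weaker inhibitor, a lower number a stronger inhibitor: compound 2 gives 63600 nM, while compound 1 `O=C(Nc1ccc(Cl)cc1)c1cc(Oc2ccc(/C=C/c3ccccn3)cc2)ccn1` gives 16200 nM. Going by the values given here, the single change between them, a 3.9-fold higher number from compound 1 to compound 2 (0.59 log units; beyond the scatter), shows that exchanging the group on the amide nitrogen moves the number by a modest amount. Compound 3 `O=C(NC1CCCCC1)c1cc(Oc2ccc(/C=C/c3ccccn3)cc2)ccn1` differs from compound 2 at that same position: cyclohexyl in place of 4-methoxybenzyl on an amide-type nitrogen. Among the compounds with values here, only the step from compound 1 to compound 2 bears on this change, and it was modest, so a step of similar or smaller size is expected in this assay. Within the data shown here, no measured compound carries a non-aromatic ring at this position, and the direction is therefore open. The estimate for compound 3 is 40000 nM, with a range from 12000 nM to 130000 nM, an expected step of a 1.6-fold lower number from compound 2 to compound 3 (0.20 log units; within the scatter).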

Compound 3, half-maximal inhibitory concentration: 12500 nM
Compound 3: the middle estimate sits 3.2-fold (0.51 log units) above what was measured; low and high end bracket the measured number.
By their numbers in this assay, from the lowest: compounds 3 and 1 (each within the scatter of the next); then compound 2.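

In this assay, the step of a 5.1-fold lower number from compound 2 to compound 3 (0.71 log units; beyond the scatter) shows that a non-aromatic ring is accepted on the amide nitrogen, and that the change away from 4-methoxybenzyl can lower the number. The step of a 1.3-fold lower number from compound 1 to compound 3 (0.11 log units; within the scatter) lies within the scatter, so cyclohexyl and 4-chlorophenyl cannot be told apart here, and an aromatic ring directly on this nitrogen is not needed to reach that level; of the three groups, only 4-methoxybenzyl stands apart. No measurement given here explains why these groups differ.

A plain benzyl group would help show whether the higher number of compound 2 goes with the methoxy group or with the benzyl group itself. Open chains such as n-butyl, and rings carrying an amine, also remain untested among the compounds shown.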